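This account rests on a few compounds, and the source may have more. Where it says the series, first, only, none or still open, it means among the compounds named here.

Working notes on the series. In an ADME assay on CHO cells (Cricetulus griseus) for inhibition, read by MTT assay (on this read-out lower numbers stand for stronger inhibition and higher numbers for weaker inhibition), compound 1 `CCNCc1cc(C)cc(Nc2nc3ccccc3n2Cc2ccc(C(F)(F)F)cc2)c1O` gives 18800 nM, the lowest of the two numbers in hand. Compound 2 `CCNCc1cc(Cl)cc(Nc2nc3ccccc3n2Cc2ccc(C(F)(F)F)cc2)c1O` gives 33800 nM, and the step of a 1.8-fold higher number from compound 1 to compound 2 (0.25 log units; within the scatter) puts chloro in place of methyl on an aromatic carbon. Compound 3 `CCN(CC)Cc1cccc(Nc2nc3ccccc3n2Cc2ccc(C#N)cc2)c1O` reaches only a limit of this assay, > 50000 nM, as set out in the limit of > 50000 nM in this assay, at which 1 of the 3 values shown sits. Compound 4 `CCN(CC)Cc1cc(C)cc(Nc2nc3ccccc3n2Cc2ccc(C(F)(F)F)cc2)c1O` differs from compound 1 by ethyl in place of hydrogen on an amine nitrogen. Going by the values given here, no measured step covers this change on the amine nitrogen; the one measured step lies within the scatter. For compound 4 a step of a 1.3-fold higher number from compound 1 to compound 4 (0.11 log units; within the scatter) is expected, not beyond the scatter. Compound 4 is therefore estimated at 24000 nM, between 10000 nM and 60000 nM.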

Compound 4, half-maximal inhibitory concentration in the CHO assay: 29300 nM
Beside the measured number, compound 4's estimate is 1.2-fold (0.09 log units) below it, and the stated range covers the measured number.
By their numbers in the CHO assay, from the lowest: compounds 1, 4 and 2 (each within the scatter of the next). At a limit, above all of these: compound 3.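

In the CHO assay the change from ethylamino to diethylamino gives a 1.6-fold higher number from compound 1 to compound 4 (0.19 log units; within the scatter), so the added ethyl on the amine nitrogen does not separate the two compounds on this read-out. Going by these compounds alone, in a physicochemical assay for solubility, read by HPLC, measured as kinetic solubility, with a stated time of 24 h, at pH 6.5 (on this read-out lower numbers stand for lower solubility and higher numbers for higher solubility), compound 1 gives 35000 nM, and the same change brings an at least 7.0-fold lower number from compound 1 to compound 4 (0.84 log units; beyond the scatter), the first step beyond the scatter. In the physicochemical assay compound 4 gives < 5000 nM, which is a limit of the assay.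

Going by these compounds, how a longer chain or a hydroxyethyl group on this amine nitrogen reads in the CHO assay and the physicochemical assay stays open. Also open, on these data alone, is whether the change reads alike with chloro in place of methyl on the aromatic carbon.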